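The source may hold more compounds than are shown below. What is called first, only, known or untested is meant among the compounds shown, and "the series" means these compounds.

Measured so far in a physicochemical assay for lipophilicity, at pH 7.4; a lower number here means a more polar compound, a higher number a more lipophilic compound:

- compound 1, `CNC(=O)c1cc(C(=O)NC2CC2)cc2c1O[C@H](CF)[C@H]2c1ccccc1`: 3.9
- compound 2, `CNC(=O)c1cc(C(=O)Nc2cnn(C)c2)cc2c1OC[C@H]2c1ccccc1`: 3.5
- compound 3, `CC[C@@]1(c2ccccc2)COc2c(C(=O)NC)cc(C(=O)N[C@H]3[C@@H]4COC[C@@H]43)cc21`: 4.2

Compound 2 stands lowest of the three numbers in this assay. The nearest to it is compound 1, whose number is higher by a margin beyond the scatter; the furthest is compound 3, higher again, also beyond the scatter. Among the measured compounds shown here, no pair among the three differs in only one place, so no single step between measured compounds can be read off directly; the values show only that compound 2 is the most polar of the set as measured.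

The next compound is compound 4, `CNC(=O)c1cc(C(=O)N[C@H]2C[C@@H]2C)cc2c1OC[C@H]2c1ccccc1`. It is compound 2 with one change:

2-methylcyclopropyl in place of 1-methyl-1H-pyrazol-4-yl on an amide-type nitrogen

The group that leaves carries two hydrogen-bond acceptors and is aromatic; the group that enters is a three-membered ring of carbon only, with no acceptors and two defined stereocentres. In this assay a step upward is expected, beyond the scatter. The scale of the step is suggested by compound 1, which also carries an amide to a small carbocycle at this position and gives 3.9 in this assay; compound 1 differs from compound 4 in other places too, so it serves as a guide rather than a direct comparator.

Compound 4 is expected at 4.1, with a range from 3.7 to 4.5. This estimate means an expected step of a number 0.60 log units higher from compound 2 to compound 4 (beyond the scatter), upward and beyond the scatter.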

Compound 4, distribution coefficient: 4.5
For compound 4 the middle estimate is 0.40 log units below the measured one, within the range that was stated.
By their numbers in this assay, from the lowest: compound 2; then compounds 1, 3 and 4 (each within the scatter of the next, the first and the last beyond it).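

Among the compounds shown here, with this assay as the read-out, 2-methylcyclopropyl in place of 1-methyl-1H-pyrazol-4-yl on an amide-type nitrogen gives a number 1.00 log units higher from compound 2 to compound 4 (beyond the scatter), the first step with only one place changed. The group on this nitrogen can therefore move the number beyond the scatter on its own, with the shared core held constant. Nothing measured here bears on the origin of this step.

For the compounds shown here, the single pair does not separate the loss of the aromatic ring, the arrival of the three-membered carbon ring, the methyl on that ring and the two defined stereocentres, so it remains open which of these features carries the step, and whether another stereoisomer of 2-methylcyclopropyl would give the same number. Also open, as far as these compounds go, are where a pyridine ring, a longer chain such as n-butyl or a carboxylic acid on this nitrogen would fall on this scale, and whether a step of similar size would appear on a core carrying other changes, such as that of compound 1 or compound 3.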